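Selenocyanate moved onto the ring: expectation for compound 3

This account rests on a few compounds, and the source may have more. Where it says the series, first, only, none or still open, it means among the compounds named here.

Two measured compounds anchor this series. Compound 1 `COc1ccc(N(C)c2nc(C)nc3ccccc23)cc1OCCCCC[Se]C#N` carries its selenium-bearing group on a chain that hangs from the ring oxygen; in a functional assay on MDA-MB-231 cells (Homo sapiens) for inhibition, read by MTT assay, with a stated time of 48 h (a lower number here means a stronger inhibitor, a higher number a weaker inhibitor), compound 1 gives 4410 nM. Compound 2 `Cc1nc(N(C)c2ccc([Se]C#N)c(F)c2)c2ccccc2n1` carries the selenium directly on the aromatic carbon, with a fluorine on the same ring and no methoxy group; in this assay compound 2 gives 6 nM. Compound 1 stands at the highest of the two numbers, and its gap to compound 2 lies well beyond the scatter, so the two values show a large spread within this small set.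

Compound 3 `COc1ccc(N(C)c2nc(C)nc3ccccc23)cc1[Se]C#N` is the shortened analogue of compound 1: a group of 3 heavy atoms (1 carbon, 1 nitrogen, 1 selenium; no ring) in place of a group of 9 heavy atoms (6 carbon, 1 nitrogen, 1 oxygen, 1 selenium; no ring), on an aromatic carbon. Going by the values given here, no measured pair differs in just this one place, so the size of the step has to be judged from what compound 1 and compound 2 show. The step of a 74-fold lower number from compound 1 to compound 3 (1.87 log units; beyond the scatter) is expected to be large and toward a lower number, because compound 2 gives 6 nM with the selenium directly on the ring, although compound 2 also differs at other places, so the estimate stays broad. For compound 3 in this assay the expected value is 60 nM, with a range from 10 nM to 400 nM.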

Compound 3, half-maximal inhibitory concentration: 52 nM
For compound 3 the middle estimate is 1.2-fold (0.06 log units) above the measured one; the measured number falls inside the stated range.
By their numbers in this assay, from the lowest: compound 2; then compound 3; then compound 1.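

Going by these compounds alone, with the rest of the structure held constant, placing the group of 3 heavy atoms in place of the group of 9 heavy atoms on this aromatic carbon, ortho to a methoxy group, gives an 85-fold lower number from compound 1 to compound 3 (1.93 log units; beyond the scatter) in this assay, the first comparison that differs in one place only. This position is therefore highly sensitive to the group it carries, and with the methoxy group retained, compound 3 still gives 52 nM, so that group does not prevent a low number when the selenium-bearing group sits directly on the aromatic carbon. Nothing available bears on the reason for the size of this step.

Going by these compounds, the step removes the chain and the link through oxygen in a single change, so its share between the two remains open: a shorter chain on the same oxygen, ending in the same selenium-bearing group, would show whether the number moves gradually with length or only on direct attachment. Also open, on these data alone, is how a thiocyanate or a plain nitrile on this aromatic carbon would read in this assay, which would show whether selenium itself is needed at this position.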